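The source may report more compounds than this note shows. Statements on the series, on what has been measured and on what is new or still open speak of the compounds shown alone.

In a functional assay on MCF7 cells (Homo sapiens) for inhibition, read by MTT assay, with a stated time of 48 h (a higher number here means a weaker inhibitor, a lower number a stronger inhibitor), three compounds of one series have been measured. Compound 1 `C=C1C(=O)N(c2ccccc2)N(c2ccccc2)C1c1ccccc1` gives 4500 nM. Compound 2 `C=C1CN(C)N(c2ccc(Cl)cc2)C1=O` gives 45200 nM. Compound 3 `C=C1C(=O)N(c2ccccc2)N(C)C1c1ccc(OC)cc1` gives 75000 nM. Compound 3 carries the largest of the three numbers, but its gap to compound 2 lies within the usual scatter of this assay, so the two cannot be told apart; its gap to compound 1 lies beyond the scatter, and compound 1 is the clearly stronger inhibitor of the pair.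

The next compound, compound 4 `C=C1C(=O)N(c2ccccc2)N(C)C1c1ccccc1`, differs from compound 3 in one place: hydrogen in place of methoxy on an aromatic carbon. Within the data shown here, no measured pair in this set shows the effect of this exact exchange, so nothing can be read directly from the data about its size. Compound 4 shares with compound 1 the unsubstituted phenyl at the carbon, and compound 1 gives 4500 nM, which leaves room for a move toward lower numbers; but the two compounds also differ elsewhere, so that comparison is only a hint.

Compound 4 is therefore expected to give about 40000 nM in this assay, within a range from 15000 nM to 110000 nM. The estimated change from compound 3 to compound 4 is a 1.9-fold lower number from compound 3 to compound 4 (0.27 log units; within the scatter), a modest step toward a lower number that may not exceed the scatter.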

Compound 4, half-maximal inhibitory concentration: 84400 nM
The estimate for compound 4 lay 2.1-fold (0.32 log units) below the measured number; the range from low to high includes it.
By their numbers in this assay, from the lowest: compound 1; then compounds 2, 3 and 4 (each within the scatter of the next).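

In this assay, putting hydrogen in place of methoxy on the aromatic carbon para to a large group gives a 1.1-fold higher number from compound 3 to compound 4 (0.05 log units; within the scatter), so this single pair separates neither compound from the other and shows no measurable effect of this exchange at this position. Among these compounds, the exchange on the amine nitrogen in a ring behaves quite differently: methyl in place of phenyl gives a 19-fold higher number from compound 1 to compound 4 (1.27 log units; beyond the scatter), the first single-place step in this set to go beyond the scatter, and in these compounds the group on that nitrogen therefore counts for far more than the methoxy does. No supporting evidence is available to explain either step.

The methoxy result rests on one pair and says nothing about how a chlorine, an amine or a carboxylic acid would behave on that aromatic carbon, or whether methoxy would matter equally with phenyl on the nitrogen. From the compounds shown here alone, it also remains open whether a longer chain such as propyl or a benzyl group on that nitrogen would give a number nearer that of compound 1 or that of compound 4.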